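The compounds below may be only part of what the source reports. "The series", "measured", "known", "first", "only" and "open" are said of these compounds alone.

Working notes on the series. Three analogues on a shared core have been run in a functional assay on the whole organism for inhibition, with Mus musculus as the target; a higher number here means that more compound is needed for the effect, a lower number that less compound is needed. Compound 1 `CCN1CCCC1CNC(=O)c1cc(NS(=O)(=O)NC)ccc1OC` gives in this assay > 50 mg/kg, which is a limit of the assay and not a number. Compound 2 `CCN1CCCC1CNC(=O)c1cc(NS(=O)(=O)NC)c(C)cc1OC` gives in this assay > 50 mg/kg, again a limit. Compound 3 `CCN1CCCC1CNC(=O)c1cc(N(C)S(N)(=O)=O)ccc1OC` gives in this assay > 50 mg/kg, also a limit. The change from compound 1 to compound 2, (methyl in place of hydrogen on an aromatic carbon), gives a step that the two limits leave unreadable from compound 1 to compound 2. The change from compound 1 to compound 3 gives a step that the two limits leave unreadable from compound 1 to compound 3. All three values sit at the limit of > 50 mg/kg in this assay, at which 3 of the 3 values shown sit.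

Compound 4 `CCN1CCCC1CNC(=O)c1cc(N(C)S(N)(=O)=O)c(C)cc1OC` is not yet measured in this assay. It differs from compound 3 by methyl in place of hydrogen on an aromatic carbon. This is the same kind of change as from compound 1 to compound 2, but the place differs: in compound 4 the methyl enters ortho to a methyl(sulfamoyl)amino group, in compound 2 ortho to a (methylsulfamoyl)amino group. The two cores differ by methyl(sulfamoyl)amino in place of (methylsulfamoyl)amino on an aromatic carbon.

Since compound 3 sits at a limit, > 50 mg/kg, the step to compound 4 is expected to be a step that the limit leaves unreadable from compound 3 to compound 4. For compound 4 the estimate in this assay is 60 mg/kg, from 25 mg/kg to 150 mg/kg, most likely again a limit.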

Compound 4, dose for half-maximal effect: > 50 mg/kg
Compound 4 ended at the assay's limit; the forecaster's own chance of this, stated with the estimate: 85%; the middle value does not contradict the limit.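

In this assay compound 4 gives > 50 mg/kg, which is a limit and not a number. The steps to compound 4 from compound 2 and from compound 3 therefore cannot be read, and the series sits at one value: the limit of > 50 mg/kg in this assay, at which 4 of the 4 values shown sit. The compounds shown leave open whether either change on the shared core alters the dose needed.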